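Weak Starting Point, Sulfonamide Swapped for Carboxylic Acid

The source may report more compounds than this note shows. Statements on the series, on what has been measured and on what is new or still open speak of the compounds shown alone.

Of the compounds shown here, two have been measured in an assay on microsomes from brain for inhibition of Fatty-acid amide hydrolase 1 (Rattus norvegicus), read by fluorescence and HPLC, with a stated time of 60 min; on this read-out lower numbers stand for stronger inhibition and higher numbers for weaker inhibition. Compound 1 `CCCCCCCCc1ccc(OCC(=O)Cn2nnc(-c3ccc(Cl)cc3)n2)cc1` gives 35 nM, while compound 2 `CCCCCCCCc1ccc(OCC(=O)Cn2nnnc2-c2cccc(S(=O)(=O)N(C)C)c2)cc1` gives 1900 nM, the higher of the two numbers and thus the weaker inhibitor of the pair. Compound 3 `CCCCCCCCc1ccc(OCC(=O)Cn2nnnc2-c2ccc(C(=O)O)cc2)cc1` is the next compound in the series and differs from compound 2 in one place: 4-carboxyphenyl in place of 3-(dimethylsulfamoyl)phenyl on an aromatic carbon. Among the measured compounds shown here, no comparable step between measured compounds exists, so the expectation rests on compound 2 alone. A change of modest size in either direction, or none beyond the scatter, is expected, so that a 1.6-fold higher number from compound 2 to compound 3 (0.20 log units; within the scatter) is estimated. Compound 3 is therefore expected to give about 3000 nM, within a range from 600 nM to 15000 nM.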

Compound 3, half-maximal inhibitory concentration: 3400 nM
For compound 3 the middle estimate is 1.1-fold (0.05 log units) below the measured one, within the range that was stated.
By their numbers in this assay, from the lowest: compound 1; then compounds 2 and 3 (each within the scatter of the next).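

Replacing 3-(dimethylsulfamoyl)phenyl with 4-carboxyphenyl on this aromatic carbon of the shared core leaves this assay essentially unmoved (a 1.8-fold higher number from compound 2 to compound 3 (0.25 log units; within the scatter)). On this read-out, the two groups cannot be told apart at this position. The swap changes both the substituent and its place on the phenyl ring, so neither can be credited separately, and nothing available bears on why the two groups read alike.

Still open, going by these compounds, is how an unsubstituted phenyl, or a phenyl carrying an amine or a nitrile, would read at this place.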